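The compounds below may be only part of what the source reports. "The series", "measured", "known", "first", "only" and "open" are said of these compounds alone.

Going by the values given here, compound 2 `O=C(CNc1ccc(Br)cc1)Nn1c(-c2ccccc2)nc2ccccc2c1=O` is one of three compounds measured in a functional assay on MCF7 cells (Homo sapiens) for cytotoxicity, read by MTT assay, with a stated time of 4 h; a lower number here means a stronger inhibitor, a higher number a weaker inhibitor. Compound 1 `CCc1ccc(NCC(=O)Nn2c(-c3ccccc3)nc3ccccc3c2=O)cc1` gives 2420 nM, compound 2 gives 15100 nM, and compound 3 `O=C1N=C(NN2Cc3ccccc3N=C2c2ccccc2)S/C1=C/c1ccc(O)cc1O` gives 7490 nM. Compound 2 has the highest of these three numbers, although its gap to compound 3 lies within the usual scatter, while its gap to compound 1 lies beyond it. Compound 4 `O=C(CNc1ccccc1)Nn1c(-c2ccccc2)nc2ccccc2c1=O` differs from compound 2 by hydrogen in place of bromo on an aromatic carbon. Among the compounds with values here, the only measured step that touches this position is a 6.2-fold higher number from compound 1 to compound 2 (0.80 log units; beyond the scatter), where the bromo arrived in place of ethyl. Removing the bromo is therefore expected to bring the number back down by a modest amount, a 2.5-fold lower number from compound 2 to compound 4 (0.40 log units; beyond the scatter). Compound 4 is accordingly estimated at 6000 nM, with a range from 2000 nM to 20000 nM.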

Compound 4, half-maximal inhibitory concentration: 15300 nM
Beside the measured number, compound 4's estimate is 2.6-fold (0.41 log units) below it, and the stated range covers the measured number.
By their numbers in this assay, from the lowest: compound 1; then compounds 3, 2 and 4 (each within the scatter of the next, the first and the last beyond it).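

Bromo and hydrogen on this aromatic carbon cannot be told apart in this assay, since the swap gives a 1.0-fold higher number from compound 2 to compound 4 (0.01 log units; within the scatter) and so the bromo adds nothing measurable here. Ethyl is what sets this position apart, with a 6.3-fold higher number from compound 1 to compound 4 (0.80 log units; beyond the scatter) and thus a real gap to hydrogen as well as to bromo. Nothing available explains this difference. Still open, on these data alone, is whether a longer chain such as propyl, a smaller methyl, or an amine or carboxylic acid on this carbon would behave like ethyl or like hydrogen.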